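Extending the butyl chain of compound 2

This account rests on a few compounds, and the source may have more. Where it says the series, first, only, none or still open, it means among the compounds named here.

In a functional assay on MCF7 cells (Homo sapiens) for antiproliferative activity, with a stated time of 5 days (on this read-out lower numbers stand for stronger inhibition and higher numbers for weaker inhibition), compound 1 `COc1ccc(-c2[nH]c3ccc(C(C)C)cc3c2C=C(C#N)C#N)cc1` gives 310 nM, while compound 2 `CCCCc1ccc2[nH]c(-c3ccc(OC)cc3)c(C=C(C#N)C#N)c2c1` gives 13 nM, the lower of the two numbers. Compound 3 `CCCCCCc1ccc2[nH]c(-c3ccc(OC)cc3)c(C=C(C#N)C#N)c2c1` extends that butyl chain: ethyl in place of hydrogen on a saturated chain carbon, four bonds along the chain from an aromatic carbon. Within the data shown here, only one measured step bears on this change, butyl in place of isopropyl, a large step of a 24-fold lower number from compound 1 to compound 2 (1.38 log units; beyond the scatter). That single step cannot show whether a longer chain would continue the trend, so no large further gain is assumed. The expected step is small, a 1.2-fold higher number from compound 2 to compound 3 (0.09 log units; within the scatter), toward a slightly higher number and probably within the scatter. Compound 3 is estimated at 16 nM, with an expected range of 4 nM to 65 nM.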

Compound 3, half-maximal inhibitory concentration: 25 nM
For compound 3 the middle estimate is 1.6-fold (0.19 log units) below the measured one, within the range that was stated.
By their numbers in this assay, from the lowest: compounds 2 and 3 (each within the scatter of the next); then compound 1.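

Going from butyl to hexyl at this position gives a 1.9-fold higher number from compound 2 to compound 3 (0.28 log units; within the scatter), so the large drop seen on leaving isopropyl does not carry on along the chain. The hexyl chain still keeps a large step over the branched group, with a 12-fold lower number from compound 1 to compound 3 (1.09 log units; beyond the scatter), which leaves compound 2 and compound 3 together, apart from compound 1. Nothing measured here gives a reason for either step. Still open, from the compounds shown here alone, is whether a longer chain such as octyl, or a chain ending in an amine or a carboxylic acid, would stay within the scatter of compound 3 or move beyond it.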